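Moving the carboxy on the ether-linked ring in compound 2

The compounds below may be only part of what the source reports. "The series", "measured", "known", "first", "only" and "open" are said of these compounds alone.

Compound 2 `Cc1c(OCCCCOc2ccccc2C(=O)O)ccc(C(=O)CC2CCCC2)c1O` is measured in an assay on HEK293 cells for positive allosteric modulation of metabotropic glutamate receptor 3 (Rattus norvegicus), read by thallium flux, with a stated time of 2.5 min (on this read-out lower numbers stand for smaller maximal responses and higher numbers for larger maximal responses), where compound 2 reaches 32.9%. Of the three values seen, this is the second highest. Compound 1 `Cc1c(OCCCCOc2ccccc2C(=O)O)ccc(C(=O)CC2CCCC2)c1C` gives 28%, and the step of a number 4.9 percentage points higher from compound 1 to compound 2 (within the scatter) lies within the scatter. Among the compounds with values here, compound 3 `CCCC(=O)c1ccc(OCCCCOc2cc(C(=O)O)ccc2OC)c(C)c1O` gives 64.2%, a number beyond the scatter above compound 2; it differs from compound 2 in several places, so no single step joins the two.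

Compound 4 `Cc1c(OCCCCOc2ccc(C(=O)O)c(Cl)c2)ccc(C(=O)CC2CCCC2)c1O` has not yet been measured. It differs from compound 2 in the aryl group on the ether oxygen: 4-carboxy-3-chlorophenyl in place of 2-carboxyphenyl on an oxygen on a saturated carbon. Within the data shown here, no measured step changes this part of the molecule, and the only step at hand, the hydroxy in place of methyl on an aromatic carbon, concerns a different ring. The expectation for compound 4 therefore rests on little, and the step of a number 9.1 percentage points higher from compound 2 to compound 4 (within the scatter) is expected to stay near the scatter, with a slight upward lean because compound 3, carrying its carboxy at another place on that ring, gives 64.2%. Compound 4 is estimated to reach 42%, between 18% and 70%.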

Compound 4, largest response reached (reported as percent of maximum), in percent of the reference or control that the assay uses: 40%
Compound 4: middle estimate off by 2 percentage points, on the high side; the range from low to high includes it.
By their numbers in this assay, from the lowest: compounds 1, 2 and 4 (each within the scatter of the next, the first and the last beyond it); then compound 3.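

In this assay, putting 4-carboxy-3-chlorophenyl in place of 2-carboxyphenyl on the oxygen gives a number 7.1 percentage points higher from compound 2 to compound 4 (within the scatter). Within the data shown here, this is the first measured step at the aryl group on the ether oxygen, and it shows that this group can be exchanged without a change in maximal response that stands clear of the scatter. Nothing on hand explains this result or shows how the moved carboxy and the added chlorine each contribute.

The compounds shown leave open what each of these two changes does alone, which the same aryl group without its chlorine would help to separate. Also open, from the compounds shown here alone, is how the response would respond to a bromine in place of the chlorine, or to a tetrazole in place of the carboxylic acid.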